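The compounds below may be only part of what the source reports. "The series", "measured", "known", "first", "only" and "open" are said of these compounds alone.

In a functional assay on PC-3 cells (Homo sapiens) for cytotoxicity, read by MTT assay, with a stated time of 72 h (on this read-out higher numbers stand for weaker inhibition and lower numbers for stronger inhibition), compound 3 `COc1cc2ncnc(Nc3ccc(F)c(Cl)c3)c2cc1NC(=O)N/N=C/c1cccc(Cl)c1Cl` gives 24400 nM. This lies within the scatter of compound 2 `COc1cc2ncnc(Nc3ccc(F)c(Cl)c3)c2cc1NC(=O)N/N=C/c1ccc([N+](=O)[O-])cc1` at 32400 nM. It lies beyond the scatter of compound 1 `O=C(N/N=C/c1ccc(O)c(Br)c1)Nc1cc2c(Nc3ccc(F)c(Cl)c3)ncnc2cc1O[C@H]1CCOC1`, which gives the lower number of 5230 nM.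

Compound 4 `COc1cc2ncnc(Nc3ccc(F)c(Cl)c3)c2cc1NC(=O)N/N=C/c1ccc(O)c(Br)c1` has 3-bromo-4-hydroxyphenyl in place of 2,3-dichlorophenyl on a carbon with a double bond to nitrogen.

Among the compounds with values here, the only measured step at this carbon, a 1.3-fold lower number from compound 2 to compound 3 (0.12 log units; within the scatter), stayed within the scatter, so exchanging the group there need not move the number much. Compound 1 also carries 3-bromo-4-hydroxyphenyl, but on a different core. Within the data shown here, no measured step separates the group from the core, so compound 1 at 5230 nM gives only a weak hint towards a lower number.

The step expected in this assay is a 1.7-fold lower number from compound 3 to compound 4 (0.24 log units; within the scatter), which means none beyond the scatter, with a lean to the lower side. For compound 4 the estimated value is 14000 nM, with an expected range of 6000 nM to 32000 nM.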

Compound 4, half-maximal inhibitory concentration: 15300 nM
Beside the measured number, compound 4's estimate is 1.1-fold (0.04 log units) below it; the measured number falls inside the stated range.
By their numbers in this assay, from the lowest: compound 1; then compounds 4, 3 and 2 (each within the scatter of the next, the first and the last beyond it).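

In this assay the group on the oxygen on an aromatic ring can now be read apart from the group on the carbon with a double bond to nitrogen: with 3-bromo-4-hydroxyphenyl held constant, methyl in place of oxolan-3-yl gives a 2.9-fold higher number from compound 1 to compound 4 (0.47 log units; beyond the scatter) and so accounts for the gap that compound 1 left unexplained. Within the data shown here, at the carbon with a double bond to nitrogen, 3-bromo-4-hydroxyphenyl in place of 2,3-dichlorophenyl gives a 1.6-fold lower number from compound 3 to compound 4 (0.20 log units; within the scatter), while in place of 4-nitrophenyl it gives a 2.1-fold lower number from compound 2 to compound 4 (0.33 log units; beyond the scatter), the first step at this place to pass the scatter, and only modestly. No measurement available here offers a reason for these steps.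

The bromine and the hydroxyl of 3-bromo-4-hydroxyphenyl remain unseparated. Also open, going by these compounds, is how an amine or a longer chain on the oxygen would compare with methyl and oxolan-3-yl.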